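Lengthening the ester chain again: expected cytotoxicity

A few compounds are considered here, and "the series" means these few. Any claim that something is new, unique, unknown or untested is made for them only; others in the source may bear on it.

Measured so far:
compound 1 `CCCCOC(=O)CCC(=O)N1CCN(CCCOc2cc3c(Nc4ccc(F)c(Cl)c4)ncnc3cc2OC)CC1`: 36.9%
compound 2 `CCCCCCCCCCCOC(=O)CCC(=O)N1CCN(CCCOc2cc3c(Nc4ccc(F)c(Cl)c4)ncnc3cc2OC)CC1`: 2.8%

Going by the values given here, in a functional assay on A549 cells (Homo sapiens) for cytotoxicity, read by MTT assay, with a stated time of 24 h, tested at 80 uM (on this read-out higher numbers stand for a weaker effect at the one concentration tested and lower numbers for a stronger effect), compound 2 gives the lowest of the two numbers, and its nearest neighbour is compound 1; the one measured step, a number 34.1 percentage points lower from compound 1 to compound 2 (beyond the scatter), was large and beyond the scatter. Compound 3 `CCCCCCCCCCCCCCCCCCOC(=O)CCC(=O)N1CCN(CCCOc2cc3c(Nc4ccc(F)c(Cl)c4)ncnc3cc2OC)CC1` has not been measured. It differs from compound 2 by heptyl in place of hydrogen on a saturated chain carbon, ten or more bonds along the chain from an oxygen next to a carbonyl group.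

The step from compound 1 to compound 2 is the only one that bears on this change: the same group entered the same chain, though nearer the ester, and the number fell a long way. Compound 2, however, already stands close to the bottom of the scale, so there is little room for a further fall. The step from compound 2 to compound 3 is therefore expected to be a number 3.2 percentage points higher from compound 2 to compound 3 (within the scatter), within the scatter. Compound 3 is estimated at 6%, in the range 0% to 25%.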

Compound 3, a percentage reported as activity, at one concentration (the size of the read-out at that concentration, not a potency): 86.7%
Compound 3: middle estimate off by 80.7 percentage points, on the low side; the whole stated range lies below it.
By their numbers in this assay, from the lowest: compound 2; then compound 1; then compound 3.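

In this assay, the change of heptyl in place of hydrogen on a saturated chain carbon does not have one fixed direction along this ester chain: it gave a number 34.1 percentage points lower from compound 1 to compound 2 (beyond the scatter), but the same change made again gave a number 83.9 percentage points higher from compound 2 to compound 3 (beyond the scatter). The effect of chain length is thus not a steady trend across the compounds shown, and compound 3, at 86.7%, ends above compound 1, at 36.9%, as well as above compound 2. No measurement available here accounts for this reversal.

The compounds shown leave open at which chain length between compound 2 and compound 3 the number turns upward. They also leave open whether an amine or a carboxylic acid at the end of the chain would change the number at this one concentration.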